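Pyranone series: ring substituent swap on compound 2

The source may hold more compounds than are shown below. What is called first, only, known or untested is meant among the compounds shown, and "the series" means these compounds.

Measured compounds:
- compound 1 `CCCCCC/C=C/c1cc(C)oc(=O)c1`: > 50000 nM
- compound 2 `Cc1cc(-c2ccc(Cl)cc2)cc(=O)o1`: > 50000 nM
- compound 3 `Cc1cc(C#Cc2ccccc2)cc(=O)o1`: 4000 nM

In a functional assay on K562 cells (Homo sapiens) for inhibition (on this read-out higher numbers stand for weaker inhibition and lower numbers for stronger inhibition), compound 1 reaches only a limit, > 50000 nM. Compound 2 likewise gives only a limit in this assay, > 50000 nM. Among the compounds with values here, compound 3 is the single member of the set with a measured number in this assay, 4000 nM. Compound 2 thus stands at the limit of this assay, where two of the three values sit (the limit of > 50000 nM in this assay, at which 2 of the 3 values shown sit); no number for it is known, only that it lies beyond the range measured.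

Compound 4 `Cc1ccc(-c2cc(C)oc(=O)c2)cc1` is not yet measured. Relative to compound 2 the change is small: methyl in place of chloro on an aromatic carbon. Within the data shown here, no measured pair in the set differs in one place, so the size of such a step is not known from the data. Since compound 2 itself sits at the limit, the expected step of a number no higher from compound 2 to compound 4 (the limit leaves the size open) is taken as none beyond the scatter, and compound 4 is most likely to return a limit again. Compound 4 is estimated at 50000 nM, within 10000 nM to 250000 nM.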

Compound 4, half-maximal inhibitory concentration: > 50000 nM
Compound 4 was reported as a limit; the forecaster's own chance of this, stated with the estimate: 75%; the middle value lies on the limit itself.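

In this assay, methyl in place of chloro gives no readable step between compound 2 and compound 4, because both values are limits: the limit of > 50000 nM in this assay, at which 3 of the 4 values shown sit.

The compounds shown leave open how far past the limit compound 2 and compound 4 lie, and whether this swap changes the read-out at all.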